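The compounds below may be only part of what the source reports. "The series", "measured", "known", "first", "only" and "open" are said of these compounds alone.

Compound 1 `C[C@]1(CN2CCc3nc(-c4ccc(F)cc4)sc3C2)Cn2cc([N+](=O)[O-])nc2O1`, compound 2 `C[C@]1(CN2CCc3nc(C4CC4)ccc3C2)Cn2cc([N+](=O)[O-])nc2O1` and compound 3 `C[C@]1(CN2CCc3nc(C4CCOCC4)ccc3C2)Cn2cc([N+](=O)[O-])nc2O1` share one core and differ from one another only in the group that sits on it. In an ADME assay on Vero cells (Chlorocebus sabaeus) for cytotoxicity, read by MTT assay, with a stated time of 72 h (a lower number here means that less compound is tolerated, a higher number that more compound is tolerated), compound 1 reaches only a limit of the assay, > 32 ug/mL, rather than a number. Compound 2 gives "not determined" (no result reported) in this assay. Compound 3 likewise gives "not determined" (no result reported), so compound 3 stands without a number of its own, beside compound 2, which is also without a number. Compound 4 `C[C@]1(CN2CCc3nc(-c4cccc(F)c4F)ccc3C2)Cn2cc([N+](=O)[O-])nc2O1` differs from compound 3 by 2,3-difluorophenyl in place of oxan-4-yl on an aromatic carbon. No measured step sizes this change, so no direction is claimed beyond the scatter. Compound 4 is estimated in this assay at about 32 ug/mL, within 12 ug/mL to 64 ug/mL.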

Compound 4, half-maximal cytotoxic concentration: > 32 ug/mL
Compound 4 gave a limit, no number (the forecaster's own chance of this, stated with the estimate: 70%); the middle value lies on the limit itself.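

No step can be read between compound 3 and compound 4 in this assay; compound 4 gives only a limit of the assay, > 32 ug/mL. The compounds shown leave open how the tolerated concentration shifts among these groups on the shared core.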